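From a Limit Back to a Pyrrolidine

A few compounds are considered here, and "the series" means these few. Any claim that something is new, unique, unknown or untested is made for them only; others in the source may bear on it.

Compound 2 `CC1CN(c2c(F)cc3c(=O)c(C(=O)O)cn(C4CC4)c3c2C(F)(F)F)CC(C)N1` gives > 500 ug/mL in a functional assay on V79 cells (Cricetulus griseus) for cytotoxicity, read by colony formation (a higher number here means a weaker inhibitor, a lower number a stronger inhibitor), and this is a limit of the assay, not a number. Compound 1 `NCC1CCN(c2c(F)cc3c(=O)c(C(=O)O)cn(C4CC4)c3c2C(F)(F)F)C1`, which carries 3-(aminomethyl)pyrrolidin-1-yl, gives 38 ug/mL in this assay. For the measured compounds named here, the only measured step, an at least 13-fold higher number from compound 1 to compound 2 (1.11 log units; beyond the scatter), is large and beyond the scatter. Compound 3 `CC1(N)CCN(c2c(F)cc3c(=O)c(C(=O)O)cn(C4CC4)c3c2C(F)(F)F)C1` returns to a pyrrolidine: 3-amino-3-methylpyrrolidin-1-yl in place of 3,5-dimethylpiperazin-1-yl on an aromatic carbon. Read in reverse, the step of an at least 13-fold higher number from compound 1 to compound 2 (1.11 log units; beyond the scatter) points to a large expected move toward a lower number. For compound 3 the expected step is an at least 10-fold lower number from compound 2 to compound 3 (1.00 log units; beyond the scatter). Compound 3 is estimated at 50 ug/mL, within an expected range of 15 ug/mL to 200 ug/mL.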

Compound 3, half-maximal inhibitory concentration: 110 ug/mL
The estimate for compound 3 lay 2.2-fold (0.34 log units) below the measured number; the range from low to high includes it.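

In this assay, putting 3-amino-3-methylpyrrolidin-1-yl in place of 3,5-dimethylpiperazin-1-yl gives an at least 4.5-fold lower number from compound 2 to compound 3 (0.65 log units; beyond the scatter), so the lower number at this position is not confined to the pyrrolidine of compound 1. The two pyrrolidines still differ, with a 2.9-fold higher number from compound 1 to compound 3 (0.46 log units; beyond the scatter). From the compounds shown here alone, the full size of the move from the piperazine stays unknown, because compound 2 rests on a limit of the assay: the limit of > 500 ug/mL in this assay, at which 1 of the 3 values shown sits.

Going by these compounds, whether a plain piperazin-1-yl would fall with compound 2 or with the pyrrolidines stays open. So does whether these steps hold with a chloro group in place of the trifluoromethyl group.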